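A few compounds are considered here, and "the series" means these few. Any claim that something is new, unique, unknown or untested is made for them only; others in the source may bear on it.

Compound 1 `CC(C)(C)[C@H](C(=O)Nc1ncc(Br)s1)c1ccc(Cl)cc1` gives 95% in a functional assay on CHO cells for agonist activity at Free fatty acid receptor 2 (Homo sapiens), read by cAMP accumulation; on this read-out lower numbers stand for smaller maximal responses and higher numbers for larger maximal responses.
Compound 2 `CN(C)c1cnc(NC(=O)[C@H](c2ccc(Cl)cc2)C(C)(C)C)s1` gives 112% in this assay.

Among the measured compounds shown here, of the two numbers measured, compound 2 stands highest; its only neighbour is compound 1, and the two are separated by the step of a number 17 percentage points higher from compound 1 to compound 2 (beyond the scatter). Compound 3 `CN1CCN(c2cnc(NC(=O)[C@H](c3ccc(Cl)cc3)C(C)(C)C)s2)CC1` has not yet been measured; it differs from compound 2 by 4-methylpiperazin-1-yl in place of dimethylamino on an aromatic carbon. For the measured compounds named here, only one measured step bears on this change, a number 17 percentage points higher from compound 1 to compound 2 (beyond the scatter), which placed dimethylamino in place of bromo at the same place and gave a modest rise in maximal response. Going by the values given here, the further move from dimethylamino to 4-methylpiperazin-1-yl keeps an amino group at that place, and no measured step shows what enlarging it does, so no step beyond the scatter is expected in this assay. Compound 3 is therefore estimated at 108%, with a range from 90% to 125%. The expected step of a number 4 percentage points lower from compound 2 to compound 3 (within the scatter) is accordingly small.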

Compound 3, largest response reached (reported as efficacy), in percent of the reference or control that the assay uses: 113%
For compound 3 the middle estimate is 5 percentage points below the measured one, and the stated range covers the measured number.
By their numbers in this assay, from the lowest: compound 1; then compounds 2 and 3 (each within the scatter of the next).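

At the aromatic carbon next to the ring sulfur, enlarging the amino group from dimethylamino to 4-methylpiperazin-1-yl, which brings in a six-membered non-aromatic ring, leaves the maximal response in this assay essentially unchanged, with a number 1 percentage points higher from compound 2 to compound 3 (within the scatter) as the printed step. Set against bromo, the same group gives a number 18 percentage points higher from compound 1 to compound 3 (beyond the scatter) and so keeps the modest rise first seen with dimethylamino, showing that this position accepts a much larger cyclic amine than the earlier compounds had tested. Nothing available accounts for this insensitivity to size.

From the compounds shown here alone, whether morpholin-4-yl or unsubstituted piperazin-1-yl would hold the maximal response at this carbon remains open, as does the effect of a carboxylic acid there. These compounds also leave open how such groups affect the concentration needed for the response, since only maximal response is shown.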